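The source may report more compounds than this note shows. Statements on the series, on what has been measured and on what is new or still open speak of the compounds shown alone.

Compound 1 `Cn1c(-c2ccc(NC(=O)CSc3nc4cc(Cl)ccc4o3)cc2)nc(-c2ccccc2)c1-c1ccccc1` stands highest among the three compounds measured in a functional assay on HT-29 cells (Homo sapiens) for cytotoxicity, read by MTT assay, with a stated time of 24 h, tested at 1.6 ug/mL (on this read-out lower numbers stand for a weaker effect and higher numbers for a stronger effect at the one concentration tested), giving 17.4%, though its lead over the other two is small. Compound 2 `Cc1ccc2oc(SCC(=O)Nc3ccc(-c4nc(-c5ccccc5)c(-c5ccccc5)n4C)cc3)nc2c1` gives 15.5% in this assay, and compound 3 `Cn1c(-c2ccc(NC(=O)CSc3nc4ccccc4s3)cc2)nc(-c2ccccc2)c1-c1ccccc1` gives 15.3%. The steps among them are a number 1.9 percentage points lower from compound 1 to compound 2 (within the scatter), a number 2.1 percentage points lower from compound 1 to compound 3 (within the scatter) and a number 0.2 percentage points lower from compound 2 to compound 3 (within the scatter), so all three sit together within the scatter.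

Compound 4 `Cn1nnnc1SCC(=O)Nc1ccc(-c2nc(-c3ccccc3)c(-c3ccccc3)n2C)cc1` has not yet been measured in this assay. Relative to compound 1 the change is 1-methyl-1H-tetrazol-5-yl in place of 5-chloro-1,3-benzoxazol-2-yl on a sulfur. Among the measured compounds shown here, the steps that bear on this are those that swap the ring on the sulfur, a number 2.1 percentage points lower from compound 1 to compound 3 (within the scatter) and a number 0.2 percentage points lower from compound 2 to compound 3 (within the scatter), both within the scatter, which suggests the group on that sulfur has had little influence so far; however, no measured step introduces a tetrazole, so the comparison is only partial. Compound 4 is therefore expected to show a number 3.4 percentage points lower from compound 1 to compound 4 (within the scatter), no step beyond the scatter. The value of compound 4 in this assay is estimated at 14%, within a range from 5% to 25%.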

Compound 4, a percentage reported as activity, at one concentration (the size of the read-out at that concentration, not a potency): 49.8%
Compound 4: the middle estimate sits 35.8 percentage points below what was measured; measured number outside the range, above it.
By their numbers in this assay, from the lowest: compounds 3, 2 and 1 (each within the scatter of the next); then compound 4.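

In this assay, the group on the sulfur now proves able to move the read-out: exchanges among 5-chloro-1,3-benzoxazol-2-yl, 5-methyl-1,3-benzoxazol-2-yl and 1,3-benzothiazol-2-yl stayed within the scatter, whereas 1-methyl-1H-tetrazol-5-yl gives a number 32.4 percentage points higher from compound 1 to compound 4 (beyond the scatter), a number 34.3 percentage points higher from compound 2 to compound 4 (beyond the scatter) and a number 34.5 percentage points higher from compound 3 to compound 4 (beyond the scatter). The step is large whichever of the three groups leaves, so among these compounds the rise goes with the entering group and not with a particular leaving group. Nothing available here accounts for the rise.

The compounds shown leave open whether the rise belongs to the tetrazole itself, to having one ring in place of two, or to the methyl on that ring. A 1H-tetrazol-5-yl without the methyl, a 1-phenyl-1H-tetrazol-5-yl or a 4-methyl-1,2,4-triazol-3-yl on the same sulfur would help to separate these readings.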